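This account rests on a few compounds, and the source may have more. Where it says the series, first, only, none or still open, it means among the compounds named here.

Working notes on the series.

Compound 1 `COc1ccc2c(OCc3nnc4sc(-c5cnn(C)c5)nn34)ccnc2c1` is the reference point here. Among the measured compounds shown here, in a functional assay on EBC-1 cells (Homo sapiens) for antiproliferative activity, with a stated time of 72 h (on this read-out higher numbers stand for weaker inhibition and lower numbers for stronger inhibition), compound 1 gives 88 nM, the lowest of the two numbers so far, with only one neighbour for comparison. Compound 2 `COc1ccc2c(OCc3nnc4sc(-c5cc6ccccc6n5C)nn34)ccnc2c1` in this assay gives 149 nM; the step of a 1.7-fold higher number from compound 1 to compound 2 (0.23 log units; within the scatter) comes from 1-methyl-1H-indol-2-yl in place of 1-methyl-1H-pyrazol-4-yl on an aromatic carbon and stays within the scatter.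

Compound 3 `COc1ccc2[nH]c(-c3nn4c(COc5ccnc6cc(OC)ccc56)nnc4s3)cc2c1` has not yet been measured in this assay. Its difference from compound 1 is 5-methoxy-1H-indol-2-yl in place of 1-methyl-1H-pyrazol-4-yl on an aromatic carbon. For the measured compounds named here, the one measured step that bears on this is the step from compound 1 to compound 2, where an indol-2-yl group also replaced the pyrazole and the number moved by a 1.7-fold higher number from compound 1 to compound 2 (0.23 log units; within the scatter), within the scatter. Going by the values given here, compound 3 carries 5-methoxy-1H-indol-2-yl rather than 1-methyl-1H-indol-2-yl, and there is no measured pair that isolates that change, so the expectation rests on the single comparable step.

For compound 3 a step of a 1.5-fold higher number from compound 1 to compound 3 (0.17 log units; within the scatter) is expected, that is, nothing clearly beyond the scatter. Compound 3 is therefore estimated at 130 nM in this assay, with a range from 50 nM to 350 nM.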

Compound 3, half-maximal inhibitory concentration: 85.6 nM
Estimate against measurement, compound 3: 1.5-fold (0.18 log units) above, and the stated range covers the measured number.
By their numbers in this assay, from the lowest: compounds 3, 1 and 2 (each within the scatter of the next).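

On the aromatic carbon of the five-membered aromatic ring with 2 nitrogen and 1 sulfur, this assay gives a 1.0-fold lower number from compound 1 to compound 3 (0.01 log units; within the scatter) when 5-methoxy-1H-indol-2-yl takes the place of 1-methyl-1H-pyrazol-4-yl. This position therefore accepts a group of 11 heavy atoms with a second aromatic ring and 1 hydrogen-bond donor without a shift beyond the scatter, which the earlier pair showed only for 1-methyl-1H-indol-2-yl. The exchange between the two indol-2-yl groups gives a 1.7-fold lower number from compound 2 to compound 3 (0.24 log units; within the scatter) and also leaves the numbers unseparated, and no available evidence accounts for any of these numbers.

The two indol-2-yl groups differ in both the ring-nitrogen methyl and the methoxy group, so the compounds shown do not tell the contribution of each apart. Also open, on these data alone, is whether a group of another kind on this carbon, such as a carboxylic acid, a primary amine or a longer alkyl chain, would move the number beyond the scatter in either direction.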